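Urea terminus variation on the benzazepine amide series

The compounds below may be only part of what the source reports. "The series", "measured", "known", "first", "only" and "open" are said of these compounds alone.

Measured so far:
compound 1 `Cc1cc(C(=O)N2CCCCc3ccccc32)ccc1CNC(=O)Nc1ccccc1` — in a functional assay on HEK293 cells for agonist activity at Vasopressin V2 receptor (Homo sapiens), read by a luciferase reporter and cAMP accumulation (on this read-out higher numbers stand for an effect only at larger amounts of compound and lower numbers for an effect already at smaller amounts), compound 1 gives 130 nM
compound 2 `CCOC(=O)CNC(=O)NCc1ccc(C(=O)N2CCCCc3ccccc32)cc1C` — in this assay compound 2 gives 140 nM
compound 3 `Cc1cc(C(=O)N2CCCCc3ccccc32)ccc1CNC(=O)NCC(N)=O` — in this assay compound 3 gives 210 nM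

Compound 3 carries the highest number of the three, but its separation from the others is small: a 1.6-fold higher number from compound 1 to compound 3 (0.21 log units; within the scatter) and a 1.5-fold higher number from compound 2 to compound 3 (0.18 log units; within the scatter) both lie within the scatter, as does a 1.1-fold higher number from compound 1 to compound 2 (0.03 log units; within the scatter). All three urea termini therefore read as equivalent on the numbers at hand.

Compound 4 `Cc1cc(C(=O)N2CCCCc3ccccc32)ccc1CNC(=O)NCC(=O)N1CCCC1` is not yet measured. Relative to compound 3 the change is pyrrolidin-1-yl in place of amino on a carbonyl carbon. Going by the values given here, no measured step shows this exact change. The nearest precedents are the terminus swaps phenyl to (ethoxycarbonyl)methyl and phenyl to carbamoylmethyl, and ethoxy to amino on the carbonyl carbon, none of which moved the read-out beyond the scatter. Compound 2 and compound 3 bracket what an altered carbonyl substituent has done here, and compound 4 is expected to fall in the same band, with no step beyond the scatter, a 1.2-fold lower number from compound 3 to compound 4 (0.09 log units; within the scatter), in this assay. For compound 4 the estimate is 170 nM, with a range from 70 nM to 450 nM.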

Compound 4, half-maximal effective concentration: 100 nM
Estimate against measurement, compound 4: 1.7-fold (0.23 log units) above, and the stated range covers the measured number.
By their numbers in this assay, from the lowest: compounds 4, 1, 2 and 3 (each within the scatter of the next, the first and the last beyond it).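

Going by these compounds alone, on the carbonyl carbon of the urea terminus, pyrrolidin-1-yl in place of amino gives the first step to lie beyond the scatter, a modest one in this assay: a 2.1-fold lower number from compound 3 to compound 4 (0.32 log units; beyond the scatter), with amino and its 1 hydrogen-bond donor leaving and a five-membered non-aromatic ring with 0 hydrogen-bond donors entering. The separation holds for this pair only, since a 1.4-fold lower number from compound 2 to compound 4 (0.15 log units; within the scatter) and a 1.3-fold lower number from compound 1 to compound 4 (0.11 log units; within the scatter) both stay within the scatter, so the new terminus reads as equivalent to the ethyl ester terminus of compound 2 and the phenyl terminus of compound 1, and the terminus can carry this larger ring without any loss in the read-out. Nothing on hand accounts for the step between the two amides.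

From the compounds shown here alone, a single ring on the carbonyl carbon cannot separate the ring itself from the simple substitution of the amide nitrogen, so dimethylamino, piperidin-1-yl and morpholin-4-yl remain open at this place. Also open, going by these compounds, are a free carboxylic acid on the same carbonyl carbon and a longer chain leading from the urea nitrogen to the carbonyl.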